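The source may report more compounds than this note shows. Statements on the series, on what has been measured and on what is new or still open speak of the compounds shown alone.

Compound 1, `O=C(/C(=C\c1ccccc1F)S(=O)(=O)c1ccc(Br)cc1)c1ccc(Cl)cc1`, gives 25000 nM in a functional assay on DU-145 cells (Homo sapiens) for inhibition, read by trypan blue exclusion, with a stated time of 96 h; a lower number here means a stronger inhibitor of growth, a higher number a weaker inhibitor of growth. Compound 2, `Cc1ccc(S(=O)(=O)/C(=C/c2cccs2)C(=O)c2ccc(Cl)cc2)cc1`, gives 25000 nM in this assay, so compound 1 sits level with compound 2 at the digits shown, well within the scatter. Compound 3, `O=C(/C(=C\c1cc([N+](=O)[O-])ccc1F)S(=O)(=O)Cc1ccc(F)cc1)c1ccc(Br)cc1`, reaches only a limit of the assay, > 100000 nM, and the limit of > 100000 nM in this assay, at which 1 of the 3 values shown sits, shows how such a limit arises here. The unmeasured compound 4, `COc1ccccc1/C=C(\C(=O)c1ccc(Cl)cc1)S(=O)(=O)c1ccc(Br)cc1`, differs from compound 1 by methoxy in place of fluoro on an aromatic carbon, placed on an aromatic carbon of a six-membered aromatic ring of carbon only, ortho to a large group. Going by the values given here, since no measured pair differs in one place, the step of no change at the digits printed from compound 1 to compound 4 (within the scatter) is expected to stay within the scatter, in either direction. Compound 4 is therefore estimated at 25000 nM, between 8000 nM and 80000 nM.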

Compound 4, concentration for 50% growth inhibition: 10000 nM
Estimate against measurement, compound 4: 2.5-fold (0.40 log units) above; measured number inside the range.
By their numbers in this assay, from the lowest: compound 4; then compounds 1 and 2 (each within the scatter of the next). At a limit, above all of these: compound 3.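

Going by these compounds alone, this is the first comparison in the set that differs in one place: on an aromatic carbon ortho to a large group, methoxy in place of fluoro gives a 2.5-fold lower number from compound 1 to compound 4 (0.40 log units; beyond the scatter) in this assay. The number at this position therefore responds to the group placed there, and the step is modest. None of the evidence shown bears on the reason for this step.

The compounds shown leave open whether an ethoxy group, a hydroxyl or an amine at this position would lower the number further. They also leave open whether the same change would give a similar step on another core.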